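The source may hold more compounds than are shown below. What is called first, only, known or untested is meant among the compounds shown, and "the series" means these compounds.

Measured compounds:
compound 1 `Cc1nc(S(C)(=O)=O)ccc1Oc1ncnc(OC2CCN(C(=O)OC(C)(C)C(F)(F)F)CC2)c1F`, 47.2 nM in a functional assay on isolated protein for inhibition of Glucose-dependent insulinotropic receptor (Rattus norvegicus), read by HTRF and cAMP accumulation; on this read-out higher numbers stand for an effect only at larger amounts of compound and lower numbers for an effect already at smaller amounts
compound 2 `Cc1nc(S(C)(=O)=O)ccc1Oc1ncnc(OC2CCN(C(=O)OC(C)(C)C#N)CC2)c1F`, 1320 nM
compound 3 `Cc1nc(S(C)(=O)=O)ccc1Oc1ncnc(OC2CCN(C(=O)OC3(C(F)(F)F)CCC3)CC2)c1F`, 63.3 nM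

Compound 3 stands second highest of the three in this assay; compound 1 sits nearest and compound 2 furthest from it. The unmeasured compound 4 `Cc1nc(S(C)(=O)=O)ccc1Oc1ncnc(OC2CCN(C(=O)SC3(C)CC3)CC2)c1F` differs from compound 3 by a group of 5 heavy atoms (4 carbon, 1 sulfur; one three-membered non-aromatic ring of carbon only) in place of a group of 9 heavy atoms (5 carbon, 1 oxygen, 3 fluorine; one four-membered non-aromatic ring of carbon only), on a carbonyl carbon, so the trifluoromethyl-bearing group is gone and the oxygen next to the carbonyl becomes sulfur. Of the measured steps, a 1.3-fold higher number from compound 1 to compound 3 (0.13 log units; within the scatter) shows that changing the ring size while keeping trifluoromethyl costs little, whereas a 28-fold higher number from compound 1 to compound 2 (1.45 log units; beyond the scatter) and a 21-fold lower number from compound 2 to compound 3 (1.32 log units; beyond the scatter) show that losing trifluoromethyl is a large step. Within the data shown here, since compound 4 also loses trifluoromethyl, a step towards higher numbers is expected, though the new sulfur and cyclopropyl carry no precedent here. Compound 4 is therefore estimated at 250 nM, with a range from 50 nM to 1500 nM, an expected step of a 3.9-fold higher number from compound 3 to compound 4 (0.60 log units; beyond the scatter).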

Compound 4, half-maximal effective concentration: 166 nM
Compound 4: middle estimate off by 1.5-fold (0.18 log units), on the high side, and the stated range covers the measured number.
By their numbers in this assay, from the lowest: compounds 1 and 3 (each within the scatter of the next); then compound 4; then compound 2.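

On the carbonyl carbon whose other neighbour is the amide-type nitrogen in a ring, a group without trifluoromethyl can still give a far lower number than the nitrile-bearing group does, as the sulfur-linked methylcyclopropyl group shows with an 8.0-fold lower number from compound 2 to compound 4 (0.90 log units; beyond the scatter). Trifluoromethyl-bearing groups still keep a modest edge, with a 2.6-fold higher number from compound 3 to compound 4 (0.42 log units; beyond the scatter) and a 3.5-fold higher number from compound 1 to compound 4 (0.55 log units; beyond the scatter). The shown compounds leave open how the sulfur and the methylcyclopropyl group each contribute, and how an oxygen-linked methylcyclopropyl or sulfur-linked tert-butyl group would compare. Nothing available accounts for these steps.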